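Aryl variation on the shared core: compound 3 to compound 4

The compounds below may be only part of what the source reports. "The series", "measured", "known", "first", "only" and "open" are said of these compounds alone.

The series shares the core seen in compound 1 `COc1cc(N2C(N)=C(C#N)C(c3ccc([N+](=O)[O-])cc3)C3=C2CC(C)(C)CC3=O)cc(OC)c1OC`, which in a functional assay on Ehrlich cells (Mus musculus) for cytotoxicity (a lower number here means a stronger inhibitor, a higher number a weaker inhibitor), gives 25000 nM. Compound 2 `COc1ccc(C2C(C#N)=C(N)N(c3cc(OC)c(OC)c(OC)c3)C3=C2C(=O)CC(C)(C)C3)cc1` in this assay gives "not active" (no number reported), and compound 3 `COc1cc(N2C(N)=C(C#N)C(/C=C/c3ccccc3)C3=C2CC(C)(C)CC3=O)cc(OC)c1OC` in this assay gives "not active" (no number reported). Within the data shown here, compound 3 therefore stands without a single number; compound 1 supplies the only numeric value in the set, and compound 2 is a second entry without one. Among the measured compounds shown here, no pair of measured compounds differs in a single place, so nothing about the size of a change in this assay can be read from the three measured compounds.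

Compound 4 `COc1cc(N2C(N)=C(C#N)C(c3c(OC)ccc4ccccc34)C3=C2CC(C)(C)CC3=O)cc(OC)c1OC` differs from compound 3 by 2-methoxynaphthalen-1-yl in place of 2-phenylethenyl on a saturated ring carbon. For the measured compounds named here, with compound 3 lacking a number, no direction or size for the step to compound 4 in this assay can be stated from the data; the only numeric anchor is compound 1 at 25000 nM, and no change in the set has carried a compound beyond weak inhibition. For compound 4 in this assay the estimate is 30000 nM, with an expected range from 8000 nM to 100000 nM, and a fair chance that the read-out is again reported without a number.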

Compound 4, half-maximal inhibitory concentration: "not active" (no number reported)
Compound 4: no number reported; the estimate stays without a comparison.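

In this assay, among these compounds, compound 3 gives "not active" (no number reported) and compound 4 gives "not active" (no number reported) so no step between these two compounds can be read. No evidence bearing on this result is available. The compounds shown leave open how far 2-methoxynaphthalen-1-yl in place of 2-phenylethenyl shifts the read-out on the shared core.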